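Removing the Bromine: From Compound 2 to Compound 3

The compounds below may be only part of what the source reports. "The series", "measured", "known", "first", "only" and "open" are said of these compounds alone.

Two compounds built on one shared core have so far been examined in a functional assay on PC-3 cells (Homo sapiens) for cytotoxicity, read by sulforhodamine B assay, with a stated time of 48 h; a higher number here means a weaker inhibitor, a lower number a stronger inhibitor. Compound 1 `C=CCOc1c(Cl)cccc1C(=O)c1cccnc1` is reported in this assay at > 100000 nM, which is a limit of the assay and not a number. Among the compounds with values here, compound 2 `C=CCOc1ccc(Br)cc1C(=O)c1cccnc1` gives 59000 nM in this assay; this is the only number among the values shown, the other value sitting at the limit of > 100000 nM in this assay, at which 1 of the 2 values shown sits. Within the data shown here, no two measured compounds differ in a single place, so no measured step can be drawn between them.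

Compound 3 `C=CCOc1ccccc1C(=O)c1cccnc1` is the next compound to be measured. It differs from compound 2 by hydrogen in place of bromo on an aromatic carbon. With the bromine removed, the account expects compound 3 to come out weaker, a step of a 1.7-fold higher number from compound 2 to compound 3 (0.23 log units; within the scatter), which would carry it beyond the scatter and toward the limit at which compound 1 sits. Compound 3 is therefore estimated at 100000 nM. The expected range for compound 3 runs from 40000 nM to 300000 nM.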

Compound 3, half-maximal inhibitory concentration: 55000 nM
Compound 3: the middle estimate sits 1.8-fold (0.26 log units) above what was measured; low and high end bracket the measured number.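

In this assay, replacing the bromo group with hydrogen on the aromatic carbon para to the allyloxy group gives a 1.1-fold lower number from compound 2 to compound 3 (0.03 log units; within the scatter), so compound 2 and compound 3 cannot be told apart and the bromine has no readable effect on the number at this position. The second step, which takes away the chloro group, is an at least 1.8-fold lower number from compound 1 to compound 3 (0.25 log units; that floor lies within the scatter), and since its floor lies within the scatter, it does not establish that compound 1 and compound 3 truly differ. The value of compound 1 is a limit of the assay and not a number: the limit of > 100000 nM in this assay, at which 1 of the 3 values shown sits.

The compounds shown leave open whether any group on this aromatic carbon can move the number beyond the scatter, since only bromo and hydrogen are compared there, and an amine or a carboxylic acid might behave differently. They also leave open what a longer chain in place of the allyloxy group would do in this assay, as that group stays the same in all the compounds shown.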